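The source may report more compounds than this note shows. Statements on the series, on what has been measured and on what is new or still open speak of the compounds shown alone.

Within the data shown here, compound 3 `O=C(Nc1c(C(O)(C(F)(F)F)C(F)(F)F)ccc2ccccc12)c1cccc([N+](=O)[O-])c1` stands second highest of the three numbers known in an assay on LtK cells with ATP-sensitive inward rectifier potassium channel 11 (Homo sapiens) as the target; a higher number here means that more compound is needed for the effect, a lower number that less compound is needed: compound 3 gives 117 nM, while compound 1 `CC(=O)Nc1c(C(O)(C(F)(F)F)C(F)(F)F)ccc2ccccc12` gives 18 nM and compound 2 `CC(C)OC(=O)Nc1c(C(O)(C(F)(F)F)C(F)(F)F)ccc2ccccc12` gives 1160 nM. Compound 4 `COc1cccc(C(=O)Nc2c(C(O)(C(F)(F)F)C(F)(F)F)ccc3ccccc23)c1` differs from compound 3 by methoxy in place of nitro on an aromatic carbon. Among the measured compounds shown here, every measured step so far alters the group on the carbonyl carbon: a 64-fold higher number from compound 1 to compound 2 (1.81 log units; beyond the scatter), a 6.5-fold higher number from compound 1 to compound 3 (0.81 log units; beyond the scatter), a 9.9-fold lower number from compound 2 to compound 3 (1.00 log units; beyond the scatter). None touches a substituent on the aromatic ring of compound 3, so they show only that this assay responds strongly to changes at the carbonyl, not how it answers this one. The author therefore expects no step beyond the scatter, a 1.0-fold higher number from compound 3 to compound 4 (0.01 log units; within the scatter). Compound 4 is expected to give about 120 nM, between 40 nM and 360 nM.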

Compound 4, half-maximal effective concentration: 185 nM
For compound 4 the middle estimate is 1.5-fold (0.19 log units) below the measured one, within the range that was stated.
By their numbers in this assay, from the lowest: compound 1; then compounds 3 and 4 (each within the scatter of the next); then compound 2.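

In this assay, among these compounds, a change on the aromatic ring at this position leaves the number within the scatter, with a 1.6-fold higher number from compound 3 to compound 4 (0.20 log units; within the scatter) as the only step of this kind, so 3-nitrophenyl and 3-methoxyphenyl are not told apart here. The aryl amide's standing among the carbonyl groups holds with methoxy in place of nitro, with a 6.3-fold lower number from compound 2 to compound 4 (0.80 log units; beyond the scatter) and a 10-fold higher number from compound 1 to compound 4 (1.01 log units; beyond the scatter) as the steps that place compound 4. Nothing measured here accounts for this result. On these data alone, whether an amine or a carboxylic acid at this ring position would also stay within the scatter of compound 3 remains open.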